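Adding a Methoxy to Compound 2

A few compounds are considered here, and "the series" means these few. Any claim that something is new, unique, unknown or untested is made for them only; others in the source may bear on it.

In an ADME assay on NIH3T3 cells (Mus musculus) for cytotoxicity, read by colorimetric assay and sulforhodamine B assay, with a stated time of 96 h (on this read-out higher numbers stand for weaker inhibition and lower numbers for stronger inhibition), compound 2 `COc1ccc(/C=C/c2cccc(O)c2)c(OC)c1` gives 19600 nM and compound 3 `COc1cc(/C=C/c2ccccc2O)cc(OC)c1F` gives 14800 nM and these two values lie within the usual scatter of each other. Compound 1 `Oc1cccc(/C=C/c2cc(F)c(F)c(F)c2)c1` reports only a limit > 30000 nM and no number. Compound 4 `COc1ccc(/C=C/c2ccc(OC)c(O)c2)c(OC)c1` differs from compound 2 by a single change methoxy in place of hydrogen on an aromatic carbon with methoxy in place of hydrogen on an aromatic carbon, ortho to a hydroxy group and para to a large group. For the measured compounds named here, no measured pair shows this change, so the expectation is loose. The step expected a 2.2-fold lower number from compound 2 to compound 4 (0.34 log units; beyond the scatter) is modest and points toward a lower number in this assay and so toward stronger inhibition. For compound 4 the estimated value is 9000 nM with an expected range from 2000 nM to 30000 nM for the coming measurement.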

Compound 4, half-maximal inhibitory concentration: 2100 nM
Beside the measured number, compound 4's estimate is 4.3-fold (0.63 log units) above it; the range from low to high includes it.
By their numbers in this assay, from the lowest: compound 4; then compounds 3 and 2 (each within the scatter of the next). At a limit, above all of these: compound 1.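

In this assay, methoxy in place of hydrogen on an aromatic carbon, ortho to a hydroxy group and para to a large group, gives a 9.3-fold lower number from compound 2 to compound 4 (0.97 log units; beyond the scatter). For the compounds shown here, this is the first single change that can be read, and it shows that this position matters: the lower number stands for stronger inhibition, and the step lies beyond the scatter.

Open, from the compounds shown here alone, is whether an ethoxy group, an amine or a longer chain at the same position would move the number the same way. Nothing shown gives a reason for the size of this step.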